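The source may report more compounds than this note shows. Statements on the series, on what has been measured and on what is new or still open speak of the compounds shown alone.

Compound 3 `CCCCCCCCCCC[C@@H](C[C@@H]1OC(=O)[C@H]1CCCCCC)OC(=O)[C@@H](NC(C)=O)C(C)C` is one of three measured members of the series, alongside compound 1 `CCCCCCCCCCC[C@@H](C[C@@H]1OC(=O)[C@H]1CCCCCC)OC(=O)CCC(C)C` and compound 2 `CCCCCCCCCCC[C@@H](C[C@@H]1OC(=O)[C@H]1CCCCCC)OC(=O)CNC(=O)OCc1ccccc1`. In an assay on membranes from brain for inhibition of Fatty-acid amide hydrolase 1 (Rattus norvegicus) (on this read-out higher numbers stand for weaker inhibition and lower numbers for stronger inhibition), compound 1 gives 10400 nM. For compound 2 this assay reports only a limit, > 50000 nM. For compound 3 this assay likewise reports only a limit, > 50000 nM. Compound 3 thus sits at the limit of > 50000 nM in this assay, at which 2 of the 3 values shown sit, and is no better resolved than compound 2; only compound 1 returns a number. Compound 4 `CCCCCCCCCCC[C@@H](C[C@@H]1OC(=O)[C@H]1CCCCCC)OC(=O)[C@@H](NC(C)=O)C(C)CC`, not yet measured, differs from compound 3 by methyl in place of hydrogen on a saturated chain carbon, three bonds along the chain from an amide-type nitrogen and a carbonyl carbon. Of the measured steps, an at least 4.8-fold higher number from compound 1 to compound 3 (0.68 log units; beyond the scatter) ends at this limit, and a step that the two limits leave unreadable from compound 2 to compound 3 gives no readable size. Within the data shown here, neither step isolates a methyl for hydrogen change, and no measured pair does. Compound 4 is therefore expected to show a step that the limit leaves unreadable from compound 3 to compound 4, with a limit again the most probable outcome in this assay. The estimated value for compound 4 is 80000 nM, within 30000 nM to 250000 nM.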

Compound 4, half-maximal inhibitory concentration: 6600 nM
Compound 4: middle estimate off by 12-fold (1.08 log units), on the high side; the measured number lies below the stated range.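

In this assay, methyl in place of hydrogen on a saturated chain carbon, three bonds along the chain from an amide-type nitrogen and a carbonyl carbon, gives an at least 7.5-fold lower number from compound 3 to compound 4 (0.87 log units; beyond the scatter), so a single added carbon at this place is enough to bring a measurable number. The 1-acetamido-2-methylbutyl group also gives an at least 7.5-fold lower number from compound 2 to compound 4 (0.87 log units; beyond the scatter) and a 1.6-fold lower number from compound 1 to compound 4 (0.20 log units; within the scatter), so an amide-bearing group on this carbonyl carbon is not incompatible with the level of the isopentyl ester. Compound 2 and compound 3 remain limits and not numbers, and the step between them cannot be read: the limit of > 50000 nM in this assay, at which 2 of the 4 values shown sit.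

From the compounds shown here alone, the full size of the methyl step stays open, as its starting point is only a limit. Going by these compounds, whether a longer chain such as n-pentyl at this place, or a free amine in place of the acetamido group, would hold this level also stays open.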